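The source may hold more compounds than are shown below. What is called first, only, known or untested is meant among the compounds shown, and "the series" means these compounds.

Compound 1 `COc1cc(-c2ncnn2-c2ccccc2)cc(OC)c1OC`: > 10000 nM
Compound 2 `COc1cc(-n2ncnc2-c2ccccc2)cc(OC)c1OC`: > 10000 nM
Compound 3 `COc1cc(-n2ncnc2-c2cccc([N+](=O)[O-])c2)cc(OC)c1OC`: > 10000 nM

In a functional assay on MCF7 cells (Homo sapiens) for antiproliferative activity, read by MTT assay, with a stated time of 72 h (on this read-out higher numbers stand for weaker inhibition and lower numbers for stronger inhibition), compound 1 gives > 10000 nM, which is a limit of the assay and not a number. Compound 2 gives > 10000 nM, also a limit. Compound 3 gives > 10000 nM, again a limit. The difference between the cores of compound 1 and compound 2 is not broken down here. Compound 3 differs from compound 2 by nitro in place of hydrogen on an aromatic carbon, and the step that the two limits leave unreadable from compound 2 to compound 3 cannot be read, since (the limit of > 10000 nM in this assay, at which 3 of the 3 values shown sit). Compound 4 `COc1cc(-c2ncnn2-c2cccc([N+](=O)[O-])c2)cc(OC)c1OC`, not yet measured, carries the same change relative to compound 1, (nitro in place of hydrogen on an aromatic carbon). Because every measured value rests at the limit of > 10000 nM in this assay, at which 3 of the 3 values shown sit, the step that the limit leaves unreadable from compound 1 to compound 4 in this assay is expected only to leave compound 4 at or beyond that limit. Compound 4 is therefore estimated at 30000 nM, with a range from 8000 nM to 150000 nM.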

Compound 4, half-maximal inhibitory concentration: > 10000 nM
Compound 4 ended at the assay's limit; the forecaster's own chance of this, stated with the estimate: 85%; the middle value does not contradict the limit.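

Compound 1 and compound 4 both rest at a limit and not at a number, so no new step can be read between them: the limit of > 10000 nM in this assay, at which 4 of the 4 values shown sit. The compounds shown leave open how far any of them lies beyond that limit in this assay, and what would give a readable value there.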